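Tert-Butyl for Propoxy on the Aryl Sulfonamide Ring

A few compounds are considered here, and "the series" means these few. Any claim that something is new, unique, unknown or untested is made for them only; others in the source may bear on it.

Two sulfonamides sharing one core have been tested in an ADME assay on HCT-116 cells (Homo sapiens) for cytotoxicity, read by CellTiter-Glo, with a stated time of 72 h; a lower number here means a stronger inhibitor, a higher number a weaker inhibitor. Compound 1 `Cc1cc(Cl)cc(Cl)c1S(=O)(=O)N1CCC(N2CCC(C)CC2)CC1` returns only a limit of the assay, > 5000 nM. Compound 2 `CCCOc1ccc(S(=O)(=O)N2CCC(N3CCC(C)CC3)CC2)cc1` likewise returns only a limit, > 5000 nM. Where compound 2 stands is therefore fixed only by this limit, and both values shown sit at it (the limit of > 5000 nM in this assay, at which 2 of the 2 values shown sit), so the two compounds cannot be told apart on these numbers.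

Compound 3 `CC1CCN(C2CCN(S(=O)(=O)c3ccc(C(C)(C)C)cc3)CC2)CC1` has not yet been measured in this assay. It differs from compound 2 in one place: tert-butyl in place of propoxy on an aromatic carbon. Within the data shown here, no step between measured compounds is available to guide the expectation. Since compound 2 sits at the limit, no step beyond the usual scatter is expected, a step that the limit leaves unreadable from compound 2 to compound 3. Compound 3 is accordingly estimated at 8000 nM, within a range from 3000 nM to 30000 nM, with a strong chance that this assay again reports only a limit.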

Compound 3, half-maximal inhibitory concentration: > 5000 nM
Compound 3: no number, only a limit; the forecaster's own chance of this, stated with the estimate: 80%; the middle value does not contradict the limit.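

Compound 2 and compound 3 each return only a limit in this assay, so no step between them can be read: the limit of > 5000 nM in this assay, at which 3 of the 3 values shown sit.

The compounds shown leave open how strongly any of them acts in this assay, and whether tert-butyl and propoxy differ there at all.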